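Working notes: amide substituents and mouse microsomal half-life

The source may hold more compounds than are shown below. What is called first, only, known or untested is meant among the compounds shown, and "the series" means these compounds.

Values in an ADME assay on microsomes from liver (Mus musculus, strain CD-1) for metabolic stability, read by LC-MS, tested at 2 uM (a higher number here means that the compound lasts longer, a lower number that the compound disappears faster), follow.
- Compound 1 `Cn1ccc2ccc(-c3cc(Nc4cnccc4C(=O)NCc4cncnc4)cc4nccnc34)cc21` gives 0.4 h
- Compound 2 `Cn1cc(CNC(=O)c2ccncc2Nc2cc(-c3ccc4ccn(C)c4c3)c3nccnc3c2)cn1` gives 0.267 h
- Compound 3 `Cn1ccc2ccc(-c3cc(Nc4cnccc4C(=O)NC4CCNC(=O)C4)cc4nccnc34)cc21` gives > 1 h as a limit of the assay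

Where compound 3 stands is known only as the limit of > 1 h in this assay, at which 1 of the 3 values shown sits, and nothing finer. Compound 4 `Cn1ccc2ccc(-c3cc(Nc4cnccc4C(=O)NCC4COCCN4)cc4nccnc34)cc21` carries (morpholin-3-yl)methyl in place of 2-oxopiperidin-4-yl on an amide-type nitrogen. Within the data shown here, two steps bear on this change: an at least 2.5-fold higher number from compound 1 to compound 3 (0.39 log units; beyond the scatter) and an at least 3.7-fold higher number from compound 2 to compound 3 (0.57 log units; beyond the scatter) both bring in 2-oxopiperidin-4-yl on that nitrogen. The third, a 1.5-fold lower number from compound 1 to compound 2 (0.18 log units; within the scatter), exchanges the other two groups. None of these steps tests (morpholin-3-yl)methyl. Compound 4 keeps a six-membered non-aromatic ring, so a value nearer compound 3 is expected than a full return to compound 1 (0.4 h). The expected change in this assay is small and downward, estimated as an at least 1.4-fold lower number from compound 3 to compound 4 (0.15 log units; that floor lies within the scatter) with wide uncertainty. Compound 4 is expected at 0.7 h, with an estimated range of 0.3 h to 1.5 h in this assay as well.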

Compound 4, half-life: > 1 h
Compound 4 gave a limit, no number; the forecaster's own chance of this, stated with the estimate: 35%; middle value at least 1.4-fold (0.15 log units) from the limit.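

In this assay, morpholin-3-yl in place of pyrimidin-5-yl gives an at least 2.5-fold higher number from compound 1 to compound 4 (0.39 log units; beyond the scatter), and morpholin-3-yl in place of 1-methyl-1H-pyrazol-4-yl gives an at least 3.7-fold higher number from compound 2 to compound 4 (0.57 log units; beyond the scatter). The gain on this amide-type nitrogen is therefore no longer tied to 2-oxopiperidin-4-yl: in these four compounds, both groups with a six-membered non-aromatic ring stand clear of both groups with an aromatic ring, and none goes against this. Compound 3 and compound 4 each return a limit rather than a number, so the steps between them cannot be read: the limit of > 1 h in this assay, at which 2 of the 4 values shown sit.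

From the compounds shown here alone, how far either compound lies past that limit stays open, and so does any ranking of the two groups. Also open, going by these compounds, is whether an open-chain amine, such as a 2-(dimethylamino)ethyl chain, would give the same gain on this nitrogen.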